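The source may report more compounds than this note shows. Statements on the series, on what has been measured and on what is new or still open speak of the compounds shown alone.

Compound 2 `O=C1C=C(N2CCNCC2)CN1c1ccc(Cl)cc1` gives 3 in a physicochemical assay for lipophilicity; on this read-out lower numbers stand for lower lipophilicity and higher numbers for higher lipophilicity. Compound 1 `O=C1C=C(N2CCCC2)CN1c1ccc(Cl)cc1` gives 2.6 in this assay, and the change from compound 2 to compound 1, (pyrrolidin-1-yl in place of piperazin-1-yl on a double-bonded ring carbon), brought a number 0.40 log units lower from compound 2 to compound 1 (beyond the scatter). Compound 3 `O=C1C=C(N2CCNCC2)C(=O)N1c1ccc(F)cc1` gives 2.6 in this assay; how its core differs from the core of compound 2 is not broken down here. Compound 4 `O=C1C=C(N2CCCC2)C(=O)N1c1ccc(F)cc1` carries the same change on the core of compound 3, (pyrrolidin-1-yl in place of piperazin-1-yl on a double-bonded ring carbon), the second time this change appears among these four compounds. Since the earlier step was a number 0.40 log units lower from compound 2 to compound 1 (beyond the scatter), a step of similar size is expected here, a number 0.40 log units lower from compound 3 to compound 4 (beyond the scatter), resting on that single measured pair alone. On this basis compound 4 is estimated at 2.2, with a range from 1.8 to 2.6.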

Compound 4, partition coefficient: 2.3
Compound 4: middle estimate off by 0.10 log units, on the low side; the measured number falls inside the stated range.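

In this assay, pyrrolidin-1-yl in place of piperazin-1-yl gave a number 0.40 log units lower from compound 2 to compound 1 (beyond the scatter) on one core and a number 0.30 log units lower from compound 3 to compound 4 (within the scatter) on the other. Among these compounds, the step is therefore confirmed beyond the scatter on only one of the two cores, and these two pairs neither show that it carries over at a constant size nor support a rule beyond these compounds. Nothing available accounts for the size of either step.

As far as these compounds go, the two cores differ in more than one place, so it remains open which of those differences, if any, bears on the step. Also open, from the compounds shown here alone, is how other groups in the same place, such as morpholin-4-yl or a dimethylamino group, would compare.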